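This account rests on a few compounds, and the source may have more. Where it says the series, first, only, none or still open, it means among the compounds named here.

Measured compounds in an assay on isolated protein for displacement of a labelled ligand from 5-hydroxytryptamine receptor 6 (Homo sapiens), read by radioligand binding; on this read-out lower numbers stand for stronger inhibition and higher numbers for weaker inhibition:
- compound 1 `CCCCc1ccc(S(=O)(=O)Nc2ccc3c(c2)CN(C)C3)cc1` gives 5.01 nM
- compound 2 `Cc1ccc(-c2ccc(S(=O)(=O)Nc3ccc4c(c3)CCN(C)CC4)cc2)s1` gives 6.31 nM
- compound 3 `CN1CCc2ccc(NS(=O)(=O)c3ccc(-c4ccc(Cl)cc4)s3)cc2CC1` gives 3.98 nM

Among these three, compound 2 has the highest number, but its gap to compound 1 and its gap to compound 3 both lie within the scatter, so the three compounds cannot be told apart on this assay.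

Compound 4 `Cc1noc(C)c1-c1ccc(S(=O)(=O)Nc2ccc3c(c2)CCN(C)CC3)cc1` is not yet measured. It differs from compound 2 in one place: 3,5-dimethyl-1,2-oxazol-4-yl in place of 5-methylthiophen-2-yl on an aromatic carbon. The new group sits on an aromatic carbon of a six-membered aromatic ring of carbon only, para to a large group, where the thiophene ring stood before.

Within the data shown here, no measured pair in this set shows a change of this kind, so there is no measured step to lean on. The expectation for compound 4 is a modest weakening, a step of a 2.4-fold higher number from compound 2 to compound 4 (0.38 log units; beyond the scatter) that may sit near the edge of the scatter rather than clearly beyond it. Compound 4 is therefore estimated at 15 nM, with a range from 4 nM to 60 nM.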

Compound 4, inhibition constant: 10 nM
For compound 4 the middle estimate is 1.5-fold (0.18 log units) above the measured one; the range from low to high includes it.
By their numbers in this assay, from the lowest: compounds 3, 1, 2 and 4 (each within the scatter of the next, the first and the last beyond it).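

In this assay, putting 3,5-dimethyl-1,2-oxazol-4-yl in place of 5-methylthiophen-2-yl gives a 1.6-fold higher number from compound 2 to compound 4 (0.20 log units; within the scatter), so compound 2 and compound 4 cannot be told apart. Among these compounds, this is the first direct comparison at this position, on an aromatic carbon para to a large group, and it shows that the swap from 6 to 7 heavy atoms and from 1 to 2 hydrogen-bond acceptors leaves no measurable difference. Nothing here explains why the two compounds read alike.

From the compounds shown here alone, both groups at this position are five-membered aromatic rings, so it remains open whether a plain phenyl ring would give a similar number. The same question applies to groups of a different kind here, such as a primary amine or a carboxylic acid.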